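Compound 3 to compound 4: a change of configuration only

The compounds below may be only part of what the source reports. "The series", "measured", "known", "first", "only" and "open" are said of these compounds alone.

In an ADME assay on HFF cells (Homo sapiens) for cytotoxicity, read by neutral red uptake (a higher number here means that more compound is tolerated, a lower number that less compound is tolerated), compound 3 `Nc1ncnc2c1ncn2/C=C1\C[C@@H]1[C@H](O)CO` gives > 300000 nM, which is a limit and not a number. Compound 1 `Nc1nc2c(ncn2/C=C2\C[C@@H]2[C@H](O)CO)c(=O)[nH]1` gives > 300000 nM, also a limit. Compound 2 `Nc1nc2c(ncn2/C=C2\C[C@@H]2[C@@H](O)CO)c(=O)[nH]1` gives > 300000 nM, again a limit. The series therefore stands at the limit of > 300000 nM in this assay, at which 3 of the 3 values shown sit.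

Compound 4 `Nc1ncnc2c1ncn2/C=C1\C[C@H]1[C@@H](O)CO` differs from compound 3 as follows: the two compounds have the same atoms and bonds and differ only in configuration as drawn: 2 of 3 stereo elements differ; a stereocentre at a saturated ring carbon is drawn S in compound 3 and R in compound 4; a stereocentre at a saturated chain carbon is drawn S in compound 3 and R in compound 4. The nearest measured change is a step that the two limits leave unreadable from compound 1 to compound 2, which involves (the fact that compounds 1 and 2 differ only in the configuration as drawn). Among the compounds with values here, that step gives no size to carry over, and no measured step changes a saturated ring carbon. No step beyond the usual scatter is expected, in either direction, so the estimated step is a number no higher from compound 3 to compound 4 (the limit leaves the size open). For compound 4 the expected value is 300000 nM, with an estimated range of 100000 nM to 500000 nM.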

Compound 4, half-maximal cytotoxic concentration: 264000 nM
Compound 4: the middle estimate sits 1.1-fold (0.06 log units) above what was measured; low and high end bracket the measured number.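

In this assay compound 4 gives 264000 nM, the only number among the compounds shown. The values of compounds 1, 2 and 3 are limits. Changing the configuration at the saturated ring carbon and the saturated chain carbon together gives an at least 1.1-fold lower number from compound 3 to compound 4 (0.05 log units; that floor lies within the scatter). The step from compound 1 to compound 2 cannot be read, since both values are limits.

Going by these compounds, the two stereocentres change together in compound 4, so the contribution of each stays open. Also open, on these data alone, is how this read-out responds to an amine or a carboxylic acid on the side chain.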